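The source may report more compounds than this note shows. Statements on the series, on what has been measured and on what is new or still open speak of the compounds shown alone.

- compound 1 `CCSc1nnc(-c2ccccc2)n1C`: > 200 mg/kg
- compound 2 `Cn1c(-c2cccc3ccccc23)nnc1[S+](C)[O-]`: > 200 mg/kg
- compound 3 `Cc1ccc(-c2nnc(S(C)(=O)=O)n2C)cc1`: > 200 mg/kg

In a functional assay on the whole organism for antagonist activity, with Mus musculus as the target (a higher number here means that more compound is needed for the effect, a lower number that less compound is needed), compound 3 gives > 200 mg/kg, which is a limit of the assay and not a number. It has company, since the three measured compounds all stand at the limit of > 200 mg/kg in this assay, at which 3 of the 3 values shown sit. No order among them can be read from these results, and none of them gives a measured dose to work from.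

Compound 4 `COc1ccc(-c2nnc(S(C)(=O)=O)n2C)cc1` has methoxy in place of methyl on an aromatic carbon, para to a large group: methoxy in place of methyl on an aromatic carbon. For the measured compounds named here, no measured pair shows what a change of this kind does, so any forecast is rough. The expectation is of no shift beyond the scatter in this assay, in either direction. The estimated change is a number no higher from compound 3 to compound 4 (the limit leaves the size open), and it stays uncertain. A result that is again only a limit is quite likely. The estimate for compound 4 is 200 mg/kg, with an expected range from 90 mg/kg to 400 mg/kg.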

Compound 4, dose for half-maximal effect: > 200 mg/kg
Compound 4 gave a limit, no number; the forecaster's own chance of this, stated with the estimate: 65%; the middle value lies on the limit itself.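

Like compound 3, compound 4 stands at a limit of the assay and not at a number, so the swap of methyl for methoxy between them cannot be read: the limit of > 200 mg/kg in this assay, at which 4 of the 4 values shown sit.

The compounds shown leave open what dose of any of them gives the half-maximal effect, and which change would bring that dose down to a measurable number.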